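This account rests on a few compounds, and the source may have more. Where it says the series, first, only, none or still open, it means among the compounds named here.

This small set of compounds was tested in a functional assay on KM12 cells (Homo sapiens) for cytotoxicity, read by colony formation; a lower number here means a stronger inhibitor of growth, a higher number a weaker inhibitor of growth. Compound 1, with the structure `C=C1CCCC(C)(C)C1(O)CC/C(C)=C/CC[C@]1(C)CC[C@@H]([C@@H](C)C(=O)OC)OO1`, reached only the limit of the assay: in this assay compound 1 gives > 5000 nM, which is a limit rather than a number. Two other members of the series give numbers. Compound 2, `C=C1CCC[C@H]2[C@](C)(CC[C@]3(C)CC[C@H]([C@@H](C)C(=O)O)OO3)[C@@H](C)CC[C@]12C`, gives 940 nM in this assay. Compound 3, `C=C1CCCC(C)(C)C1CC[C@@]1(C)CC[C@H]([C@@H](C)C(=O)O)OO1`, gives 4820 nM in this assay. Where compound 1 stands can therefore be said only loosely: its value sits (the limit of > 5000 nM in this assay, at which 1 of the 3 values shown sits), so it can be placed no closer than that.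

The next compound, compound 4, has the structure `C=C1CCCC(C)(C)C1(O)CC/C(C)=C/CC[C@]1(C)CC[C@H]([C@@H](C)C(=O)OC)OO1`. Its relation to compound 1 is the narrowest kind of change: the two compounds have the same atoms and bonds; at least one stereo element is drawn with a configuration in one of them and without one in the other: 1 of 5 stereo elements differ; a stereocentre at a saturated ring carbon is drawn S in compound 1 and R in compound 4. The two share every atom and every bond, and differ only in how one centre of the ring is drawn.

Among the measured compounds shown here, no step of this kind has been measured within this set, so nothing here says how large such a change usually is. Given that compound 1 sits at the limit, the expected step from compound 1 to compound 4 is a number no higher from compound 1 to compound 4 (the limit leaves the size open), a modest move with wide uncertainty. Compound 4 is thus estimated at 5000 nM in this assay, within a range from 1500 nM to 15000 nM.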

Compound 4, concentration for 50% growth inhibition: > 5000 nM
Compound 4 gave a limit, no number; the forecaster's own chance of this, stated with the estimate: 50%; the middle value lies on the limit itself.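

Among the compounds shown here, compound 1 and compound 4 each give only a limit in this assay, not a number, so no step between them can be read: the limit of > 5000 nM in this assay, at which 2 of the 4 values shown sit. The compounds shown leave open whether the configuration at this one saturated ring carbon changes growth inhibition at all, and the drawings add a further uncertainty: the fact that one of compounds 1 and 4 is drawn with a defined configuration and the other without, at the place where they differ.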